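The source may report more compounds than this note shows. Statements on the series, on what has been measured and on what is new or still open speak of the compounds shown alone.

Measured compounds:
- compound 1 `COc1ccc(C2SCC(=O)N2CCN2CCCCC2)cc1`: in an ADME assay on Vero cells (Chlorocebus sabaeus) for cytotoxicity, read by neutral red uptake, tested at 12.3 ug/mL (a higher number here means a weaker effect of the compound at the concentration tested, a lower number a stronger effect), compound 1 gives 100%
- compound 2 `O=C1CSC(c2ccc(F)cc2)N1CCN1CCCCC1`: in this assay compound 2 gives 100%
- compound 3 `O=C1CSC(c2cccc(F)c2)N1CCN1CCCCC1`: in this assay compound 3 gives 100%

The three compounds share one core and differ only in the aromatic group that sits on it. Compound 2 and compound 3 have the same atoms joined differently: 3-fluorophenyl in place of 4-fluorophenyl on a saturated ring carbon. That change made no change at the digits printed from compound 2 to compound 3 (within the scatter). Compound 2 and compound 1 differ by methoxy in place of fluoro on an aromatic carbon, and this step made no change at the digits printed from compound 2 to compound 1 (within the scatter).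

Compound 4 `COc1cccc(C2SCC(=O)N2CCN2CCCCC2)c1` has not been measured yet. It differs from compound 3 by methoxy in place of fluoro on an aromatic carbon. Among the compounds with values here, this is the same kind of change as the one from compound 2 to compound 1, but not the same: in compound 1 the methoxy sits para to a large group, in compound 4 it sits meta to a large group.

The expectation for compound 4 rests on compound 3, which gives 100%, and on the earlier step, no change at the digits printed from compound 2 to compound 1 (within the scatter), so the step from compound 3 to compound 4 is expected to be no change at the digits printed from compound 3 to compound 4 (within the scatter). Compound 4 is therefore estimated at 100%, expected to lie between 90% and 100%.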

Compound 4, a percentage reported as activity, at one concentration (the size of the read-out at that concentration, not a potency): 100%
Compound 4: the middle estimate sits on the measured number at the digits printed; the measured number falls inside the stated range.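

In this assay, putting methoxy in place of fluoro gave no change at the digits printed from compound 3 to compound 4 (within the scatter), and this step can be set beside the same change made earlier on a second core: the same change on two cores in this assay, no change at the digits printed (within the scatter) from compound 2 to compound 1 and no change at the digits printed (within the scatter) from compound 3 to compound 4, 0 percentage points apart, within the scatter of two such steps

So, for these two pairs, the swap from fluoro to methoxy behaves alike on both cores, and knowing its outcome on one would have correctly indicated its outcome on the other. Neither step moved the read-out, however, so this is agreement between two steps with no visible size; it does not show how a change that does shift the read-out would carry from one core to another, and it says nothing about other cores or other kinds of measurement.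

The compounds shown leave open whether an amine or a carboxylic acid on the aromatic ring would give the same read-out as fluoro or methoxy. They also leave open what a longer chain, such as ethoxy or butoxy, would do in place of methoxy.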